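A few compounds are considered here, and "the series" means these few. Any claim that something is new, unique, unknown or untested is made for them only; others in the source may bear on it.

Measured so far in a functional assay on HeLa cells (Homo sapiens) for antiproliferative activity, read by MTT assay, with a stated time of 72 h (on this read-out lower numbers stand for stronger inhibition and higher numbers for weaker inhibition), are these compounds:

Compound 1 `CCn1ccnc1-c1cc(OC)c(OC)c(OC)c1` gives > 100000 nM as a limit of the assay, not a number
Compound 2 `COc1ccc(-n2ccnc2-c2cc(OC)c(OC)c(OC)c2)cc1[N+](=O)[O-]` gives 2500 nM
Compound 3 `COc1cc(-c2nccn2-c2ccc3sccc3c2)cc(OC)c1OC` gives 1400 nM

Compound 1 has no numerical value in this assay and is known only through the limit of > 100000 nM in this assay, at which 1 of the 3 values shown sits, as its standing on these numbers. The next compound, compound 4 `COc1cc(-c2nccn2-c2cccc(C)c2)cc(OC)c1OC`, has not yet been measured. Within the data shown here, it keeps the core of compound 1 and carries 3-methylphenyl in place of ethyl on an aromatic nitrogen as its single change.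

Two compounds with an aromatic ring on that nitrogen do give numbers: compound 2 reads 2500 nM and compound 3 reads 1400 nM in this assay, and neither goes against this reading of the small set. On that basis a clear move toward stronger inhibition is expected, though its size is uncertain since it starts from a limit. The expected step is an at least 25-fold lower number from compound 1 to compound 4 (1.39 log units; beyond the scatter) in that direction.

For compound 4 the estimated value is 4000 nM, with an expected range from 700 nM to 25000 nM.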

Compound 4, half-maximal inhibitory concentration: 1900 nM
Estimate against measurement, compound 4: 2.1-fold (0.32 log units) above, and the stated range covers the measured number.
By their numbers in this assay, from the lowest: compounds 3, 4 and 2 (each within the scatter of the next). At a limit, above all of these: compound 1.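

In this assay, among these compounds, 3-methylphenyl in place of ethyl on an aromatic nitrogen gives an at least 52-fold lower number from compound 1 to compound 4 (1.72 log units; beyond the scatter) as the first comparison at this position in which only that one group changes. The entering group is a six-membered aromatic ring of carbon only, with no hydrogen-bond donors or acceptors, so a step of this size at this nitrogen needs neither. Going by these compounds, compound 1 stands at a limit of the assay, so the step is a bound and its true size stays unknown: the limit of > 100000 nM in this assay, at which 1 of the 4 values shown sits.

The step cannot separate the aromatic ring from the larger size of the group, and cyclohexyl or a longer chain such as butyl on the same nitrogen would tell these apart. Plain phenyl would show what the methyl group on the ring contributes.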